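The source may report more compounds than this note shows. Statements on the series, on what has been measured and on what is new or still open speak of the compounds shown alone.

Going by the values given here, compound 2, `CC1(C)[C@H](O)C[C@@H]1Nc1nc(NCc2cnccc2C(F)(F)F)ncc1C#N`, stands at the high end of the two numbers so far: in an assay on isolated protein for inhibition of protein kinase C theta type (Homo sapiens), read by TR-FRET, with a stated time of 2 h (a higher number here means a weaker inhibitor, a lower number a stronger inhibitor), compound 2 gives 300 nM, whereas compound 1, `CC1(C)[C@@H](O)C[C@H]1Nc1nc(NCc2cnccc2C(F)(F)F)ncc1C#N`, gives 4 nM. The step of a 75-fold higher number from compound 1 to compound 2 (1.88 log units; beyond the scatter) rests on the mirror-image relationship alone, which is the fact that compounds 1 and 2 differ only in the configuration as drawn; both stereocentres on the saturated ring are inverted between them.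

Compound 3, `CC1(C)[C@@H](Nc2nc(NCc3cnccc3C(F)(F)F)ncc2C#N)C[C@@H]1O`, is the next point. From compound 2 it changes as follows: the two compounds have the same atoms and bonds and differ only in configuration as drawn: 1 of 2 stereo elements differ; a stereocentre at a saturated ring carbon is drawn R in compound 2 and S in compound 3. Compound 3 is therefore a diastereomer of both measured compounds, matching compound 1 at one ring stereocentre and compound 2 at the other. Among the compounds with values here, the only measured step that bears on it is the inversion of both centres, a 75-fold higher number from compound 1 to compound 2 (1.88 log units; beyond the scatter), which was large. Inverting one of the two centres back toward compound 1 is expected to recover part of that loss, so a decrease in this assay is expected, though not the full return to the level of compound 1. The expected step is a 5.0-fold lower number from compound 2 to compound 3 (0.70 log units; beyond the scatter). For compound 3 the estimate in this assay is 60 nM, with a range from 10 nM to 600 nM.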

Compound 3, half-maximal inhibitory concentration: 170 nM
For compound 3 the middle estimate is 2.8-fold (0.45 log units) below the measured one; the measured number falls inside the stated range.
By their numbers in this assay, from the lowest: compound 1; then compounds 3 and 2 (each within the scatter of the next).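

Compound 3 separates the two centres that were inverted together in the earlier pair. In this assay, changing only the centre drawn R in compound 1 and S in compound 3 gives a 43-fold higher number from compound 1 to compound 3 (1.63 log units; beyond the scatter), so this one inversion is enough to produce a large loss, and the difference rests on configuration alone: the fact that compounds 1 and 3 differ only in the configuration as drawn

Changing only the other centre gives a 1.8-fold lower number from compound 2 to compound 3 (0.25 log units; within the scatter), so with the first centre drawn S, the configuration at the second has no readable effect on the number, and again the pair differs in nothing else: the fact that compounds 2 and 3 differ only in the configuration as drawn Among these three compounds, the low number therefore appears only with the arrangement of compound 1, and compounds 2 and 3 sit together at the weak end.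

Still open is whether the second centre matters when the first keeps its compound 1 configuration, as the single inversion of that second centre from compound 1 is not among the compounds shown. Also open, going by these compounds, is whether this dependence on configuration would persist with an amine or a methoxy group in place of the hydroxyl.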